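The source may hold more compounds than are shown below. What is called first, only, known or untested is meant among the compounds shown, and "the series" means these compounds.

Measured so far in a functional assay on HCT-116 cells (Homo sapiens) for cytotoxicity, read by MTT assay, with a stated time of 72 h; on this read-out lower numbers stand for stronger inhibition and higher numbers for weaker inhibition:
compound 1 `Cc1cccc(CSc2cc(Cl)c(C)cc2S(=O)(=O)/N=C(\N)n2nccc2-c2ccccc2)c1` gives 6500 nM
compound 2 `Cc1cc(S(=O)(=O)/N=C(\N)n2nccc2-c2ccccc2)c(SCc2ccc(C(F)(F)F)cc2)cc1Cl` gives 14000 nM
compound 3 `Cc1cc(-c2ccccc2)n(/C(N)=N/S(=O)(=O)c2cc(C)c(Cl)cc2SCc2ccccc2C)n1` gives 42000 nM

Compound 3 carries the highest number of the three: compound 2 sits a step below it and compound 1 further still, both gaps beyond the scatter. Compound 4 `Cc1cc(S(=O)(=O)/N=C(\N)n2nccc2-c2ccccc2)c(SCc2ccccc2C)cc1Cl` differs from compound 3 by hydrogen in place of methyl on an aromatic carbon. Among the measured compounds shown here, no measured step touches this ring carbon; the single step on record, a 2.2-fold higher number from compound 1 to compound 2 (0.33 log units; beyond the scatter), concerns the group on the saturated chain carbon bound to a sulfur and does not bear on it. What does bear on it is that both compounds with hydrogen at this ring carbon give lower numbers: compound 1 gives 6500 nM and compound 2 gives 14000 nM, against compound 3 at 42000 nM. Compound 4 is therefore expected to give a lower number, a step of about a 3.5-fold lower number from compound 3 to compound 4 (0.54 log units; beyond the scatter). The estimate for compound 4 is 12000 nM, range 4500 nM to 32000 nM.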

Compound 4, half-maximal inhibitory concentration: 16000 nM
Estimate against measurement, compound 4: 1.3-fold (0.12 log units) below; measured number inside the range.
By their numbers in this assay, from the lowest: compound 1; then compounds 2 and 4 (each within the scatter of the next); then compound 3.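

In this assay, among the compounds shown here, the step of a 2.6-fold lower number from compound 3 to compound 4 (0.42 log units; beyond the scatter) is the first measured change at this ring carbon, and with the 2-methylphenyl group held fixed, hydrogen in place of methyl moves the number beyond the scatter. With hydrogen at this carbon, the group on the saturated chain carbon gives a mixed picture: a 1.1-fold higher number from compound 2 to compound 4 (0.06 log units; within the scatter) stays within the scatter, whereas a 2.5-fold higher number from compound 1 to compound 4 (0.39 log units; beyond the scatter) lies beyond it. Nothing on hand accounts for these steps.

On these data alone, whether the methyl step holds with the 3-methylphenyl or 4-(trifluoromethyl)phenyl group remains open. So does what an ethyl, a methoxy or an amine at this ring carbon would give.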